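From a trihydroxyphenyl carbonyl group to a methyl

The compounds below may be only part of what the source reports. "The series", "measured", "known", "first", "only" and "open" are said of these compounds alone.

In a functional assay on HUVEC cells (Homo sapiens) for antiproliferative activity, read by MTT assay, with a stated time of 72 h (a lower number here means a stronger inhibitor, a higher number a weaker inhibitor), compound 1 `COc1cc(O)c2c(=O)c(OC)c(-c3ccc4c(c3)OC(c3ccc(O)c(OC)c3)C(CO)O4)oc2c1` gives 8300 nM and compound 2 `COc1cc(C2Oc3cc(-c4oc5cc(O)cc(O)c5c(=O)c4O)ccc3OC2COC(=O)c2cc(O)c(O)c(O)c2)ccc1O` gives 11300 nM. Compound 2 therefore stands level with compound 1, since the two numbers lie within the usual scatter of each other and cannot be ranked.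

Compound 3 `COCC1Oc2ccc(-c3oc4cc(O)cc(O)c4c(=O)c3O)cc2OC1c1ccc(O)c(OC)c1` has not yet been measured. It keeps the rest of compound 2 and differs in one place: on an oxygen on a saturated carbon, methyl stands in place of (3,4,5-trihydroxyphenyl)carbonyl (methyl in place of (3,4,5-trihydroxyphenyl)carbonyl on an oxygen on a saturated carbon). The group that leaves is much the larger of the two, and it carries hydrogen-bond donors where methyl has none.

Among the measured compounds shown here, no measured pair of compounds shows this change on its own, so the data give no direct guide to its size or direction. The only anchor is the narrow band formed by compound 1 at 8300 nM and compound 2 at 11300 nM. No shift beyond the scatter is therefore expected in this assay. The estimated change is a 1.1-fold higher number from compound 2 to compound 3 (0.03 log units; within the scatter). For compound 3 the estimated value is 12000 nM, with an expected range of 5000 nM to 30000 nM.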

Compound 3, half-maximal inhibitory concentration: 5300 nM
The estimate for compound 3 lay 2.3-fold (0.35 log units) above the measured number; measured number inside the range.
By their numbers in this assay, from the lowest: compounds 3, 1 and 2 (each within the scatter of the next, the first and the last beyond it).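

In this assay, methyl in place of (3,4,5-trihydroxyphenyl)carbonyl on an oxygen on a saturated carbon gives a 2.1-fold lower number from compound 2 to compound 3 (0.33 log units; beyond the scatter), a modest step but one beyond the usual scatter, so this is a place where a change registers in this assay. The direction also shows that the (3,4,5-trihydroxyphenyl)carbonyl group, with its aromatic ring and hydrogen-bond donors, is not needed for the antiproliferative activity of this series: compound 3, with a single carbon in its place, gives the lower number. Nothing measured here accounts for the shift.

Among the compounds shown here, the one step removes the aromatic ring, the hydrogen-bond donors and most of the heavy atoms of the group at once, so it leaves unsettled which of these losses matters, if any does alone. Also open, on these data alone, is how an unsubstituted benzoyl, a longer alkyl chain such as butyl, or an amine in place of the oxygen would read against compound 2 and compound 3.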